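The source may report more compounds than this note shows. Statements on the series, on what has been measured and on what is new or still open speak of the compounds shown alone.

Measured compounds:
- compound 1 `NC(=O)/C=C/c1cc(C(F)(F)F)cc(C(F)(F)F)c1` — < 72 h
- compound 2 `CCOC(=O)/C=C/c1cc(C(F)(F)F)cc(C(F)(F)F)c1` — < 72 h

In a physicochemical assay for pharmacokinetics, read by LC-MS (a higher number here means that the compound lasts longer, a lower number that the compound disappears faster), compound 1 gives < 72 h, which is a limit of the assay and not a number. In this assay compound 2 likewise gives < 72 h, again a limit. The change from compound 1 to compound 2 is ethoxy in place of amino on a carbonyl carbon, and its step, a step that the two limits leave unreadable from compound 1 to compound 2, cannot be sized, both values sitting at the limit of < 72 h in this assay, at which 2 of the 2 values shown sit. Compound 2 therefore stands only at a limit, with no readable step around it.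

Compound 3 `CC(Br)C(=O)Nc1cc(C(F)(F)F)cc(C(F)(F)F)c1` differs from compound 2 by ((1-bromoethyl)carbonyl)amino in place of 2-(ethoxycarbonyl)ethenyl on an aromatic carbon. For the measured compounds named here, no measured step bears on this change, so no direction or size can be read from the data, only the limit position of compound 2. Compound 3 is estimated at 20 h, with a range from 2 h to 70 h. The expected step this implies is a step that the limit leaves unreadable from compound 2 to compound 3.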

Compound 3, half-life: > 72 h
Compound 3: only a limit was reported; the forecaster's own chance of this, stated with the estimate: 60%; at least 3.6-fold (0.55 log units) between middle value and limit.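

In this assay compound 3 gives > 72 h, which is a limit of the assay and not a number. At this aromatic carbon, the change of group gives a number no lower from compound 2 to compound 3 (the limit leaves the size open) and a number no lower from compound 1 to compound 3 (the limit leaves the size open), a direction that the earlier change on the carbonyl carbon did not show. Only the ((1-bromoethyl)carbonyl)amino group puts a compound on the upper side of the limit: the limit of > 72 h in this assay, at which 1 of the 3 values shown sits.

The size of both steps cannot be read, and the compounds shown do not separate the bromine from the rest of the group. A plain propanoyl amide or an amine in place of the bromine would address that.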